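Swapping a methoxyphenyl for a cyanophenyl on a triazole

A few compounds are considered here, and "the series" means these few. Any claim that something is new, unique, unknown or untested is made for them only; others in the source may bear on it.

Measured compounds:
- compound 1, `COc1ccc(/C=C\C(=O)O)c(OCc2cn(-c3ccc(NC(=O)c4ccccc4)cc3)nn2)c1CC=C(C)C`: 20300 nM
- compound 2, `COc1ccc(/C=C\C(=O)O)c(OCc2cn(-c3cccc(C#N)c3)nn2)c1CC=C(C)C`: 26800 nM
- compound 3, `COc1ccc(-n2cc(COc3c(/C=C\C(=O)O)ccc(OC)c3CC=C(C)C)nn2)cc1`: "not determined" (no result reported)

All three share one core: a cinnamic acid bearing a prenyl chain and a methoxy group, joined through an ether link to a triazole that carries an aryl group on its ring nitrogen. They were tested in a functional assay on COLO 205 cells (Homo sapiens) for cytotoxicity, read by MTT assay, with a stated time of 24 h; a lower number here means a stronger inhibitor, a higher number a weaker inhibitor. Compound 1, with a benzamido-substituted phenyl on the triazole, gives 20300 nM. Compound 2, with a 3-cyanophenyl there, gives 26800 nM. These two values lie within the usual scatter of each other, so nothing separates them. Compound 3, with a 4-methoxyphenyl on the triazole nitrogen, is reported as "not determined" (no result reported) in this assay, so it has no number to stand on.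

Compound 4, `COc1ccc(/C=C\C(=O)O)c(OCc2cn(-c3ccccc3C#N)nn2)c1CC=C(C)C`, differs from compound 3 in one way: 2-cyanophenyl in place of 4-methoxyphenyl on an aromatic nitrogen. With no value for compound 3, the size of the step cannot be judged from the data. Within the data shown here, compound 2 already carries a cyanophenyl on the same nitrogen and gives 26800 nM, and nothing among the measured compounds points to a change beyond the scatter for compound 4. Compound 4 is therefore expected to give about 25000 nM, with a likely range from 9000 nM to 70000 nM.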

Compound 4, half-maximal inhibitory concentration: 3200 nM
Estimate against measurement, compound 4: 7.8-fold (0.89 log units) above; measured number outside the range, below it.
By their numbers in this assay, from the lowest: compound 4; then compounds 1 and 2 (each within the scatter of the next).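

In this assay, moving the nitrile around the phenyl ring on the triazole nitrogen, with 2-cyanophenyl in place of 3-cyanophenyl, gives an 8.4-fold lower number from compound 2 to compound 4 (0.92 log units; beyond the scatter) and so shows that the place of the nitrile on this ring counts, and not merely its presence. This could not be seen before: compound 1 gives 20300 nM and compound 2 gives 26800 nM and these two lie within the usual scatter, even though their aryl groups carry quite different substituents. Nothing measured here explains why the 2-cyanophenyl group stands out.

Compound 3 has no number, so the step from its 4-methoxyphenyl to the 2-cyanophenyl of compound 4 cannot be read. It also remains open whether the nitrile itself matters or whether another group in the same ring position would do as well, as a 2-chlorophenyl or 2-methylphenyl would test, and how a 4-cyanophenyl would compare with the two cyanophenyl groups shown.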